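Ester Enlarged on a Shared Core: Expected Potency

The source may report more compounds than this note shows. Statements on the series, on what has been measured and on what is new or still open speak of the compounds shown alone.

Compound 2 `COC(=O)C1=C(C)NC(C)=C(C(=O)OC2C=CCCC2)C1c1cccc([N+](=O)[O-])c1` and compound 1 `C=CCOC(=O)C1=C(C)NC(C)=C(C(=O)OC)C1c1cccc([N+](=O)[O-])c1` share one core and differ only in one ester group. In a functional assay on HEK293 cells for antagonist activity at Voltage-dependent L-type calcium channel subunit alpha-1C (Oryctolagus cuniculus), read by FLIPR (on this read-out higher numbers stand for weaker inhibition and lower numbers for stronger inhibition), compound 1 gives 15 nM, and compound 2 gives 10 nM; the step of a 1.5-fold lower number from compound 1 to compound 2 (0.18 log units; within the scatter) leaves the two numbers indistinguishable. Compound 3 `COC(=O)C1=C(C)NC(C)=C(C(=O)OCc2ccc(OC)cc2)C1c1cccc([N+](=O)[O-])c1` carries 4-methoxybenzyl in place of cyclohex-2-en-1-yl on an oxygen next to a carbonyl group. Going by the values given here, the one measured step, a 1.5-fold lower number from compound 1 to compound 2 (0.18 log units; within the scatter), is the only guide to this change, and it was small. The expected step in this assay is therefore no change at the digits printed from compound 2 to compound 3 (within the scatter), nothing beyond the scatter. Compound 3 is accordingly estimated at 10 nM, with a range from 3 nM to 35 nM.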

Compound 3, half-maximal inhibitory concentration: 51 nM
Estimate against measurement, compound 3: 5.1-fold (0.71 log units) below, and the stated range ends below it.
By their numbers in this assay, from the lowest: compounds 2 and 1 (each within the scatter of the next); then compound 3.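

Compound 1 and compound 2 sit within the scatter of each other, but this ester position does not accept every group equally. With 4-methoxybenzyl on the oxygen, inhibition weakens beyond the scatter, with a 5.1-fold higher number from compound 2 to compound 3 (0.71 log units; beyond the scatter) and a 3.4-fold higher number from compound 1 to compound 3 (0.53 log units; beyond the scatter) in this assay. No measurement here explains why this group weakens inhibition. On these data alone, it remains open whether the aromatic ring or its methoxy group matters more, as a plain benzyl group would help show. As far as these compounds go, how an amine or a carboxylic acid on this ester chain would read also remains open.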